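Isopropyl for methyl on a fused bicyclic core

A few compounds are considered here, and "the series" means these few. Any claim that something is new, unique, unknown or untested is made for them only; others in the source may bear on it.

Measured compounds:
compound 1 `CC1CC(=O)c2s/c(=N/c3ccccc3)oc2C1` — 1890 nM
compound 2 `CC(C)C1CC(=O)c2s/c(=N/c3ccccc3)oc2C1` — 1220 nM
compound 3 `CC1CC(=O)c2s/c(=N/c3c(Cl)cc(Cl)cc3Cl)oc2C1` — a limit only, > 30000 nM

Compounds 1 and 2 share one core and compound 3 carries another; the difference between the two cores is not broken down here. In a functional assay on NUGC-3 cells (Homo sapiens) for antiproliferative activity, read by sulforhodamine B assay (a lower number here means a stronger inhibitor of growth, a higher number a weaker inhibitor of growth), compound 1 gives 1890 nM and compound 2 gives 1220 nM. The change between them is isopropyl in place of methyl on a saturated ring carbon and the step it made is a 1.5-fold lower number from compound 1 to compound 2 (0.19 log units; within the scatter). For compound 3 this assay reports only a limit, > 30000 nM, and this is the limit at which one of the three values sits (the limit of > 30000 nM in this assay, at which 1 of the 3 values shown sits).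

Compound 4 `CC(C)C1CC(=O)c2s/c(=N/c3c(Cl)cc(Cl)cc3Cl)oc2C1` is not yet measured in this assay. It stands to compound 3 as compound 2 stands to compound 1: the change is isopropyl in place of methyl on a saturated ring carbon, the same change, made at a place described in the same words. On the core of compound 1 this change gave a 1.5-fold lower number from compound 1 to compound 2 (0.19 log units; within the scatter), a step within the scatter. On that basis the step is expected to be a step that the limit leaves unreadable from compound 3 to compound 4, also within the scatter. Since compound 3 gives only the limit > 30000 nM, compound 4 is expected most likely to return a limit as well rather than a number. Should a number be obtained, compound 4 is estimated at 40000 nM, between 15000 nM and 120000 nM.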

Compound 4, concentration for 50% growth inhibition: > 30000 nM
Compound 4 was reported as a limit (the forecaster's own chance of this, stated with the estimate: 75%); the middle value is on the limit's open side.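

In this assay compound 4 gives > 30000 nM, which is a limit and not a number. Within the data shown here, compound 3 also stands at a limit, so no step between compound 3 and compound 4 can be read: the limit of > 30000 nM in this assay, at which 2 of the 4 values shown sit. The compounds shown leave open whether isopropyl in place of methyl on a saturated ring carbon shifts growth inhibition at all on the core of compound 3.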